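The source may report more compounds than this note shows. Statements on the series, on what has been measured and on what is new or still open speak of the compounds shown alone.

Measured compounds in an assay with 3-hydroxy-3-methylglutaryl-coenzyme A reductase (Rattus norvegicus) as the target; on this read-out higher numbers stand for weaker inhibition and lower numbers for stronger inhibition:
- compound 1 `CCC(C)(C)C(=O)O[C@H]1C[C@@H](C)[C@@H](O)[C@@H]2CC[C@H](C)[C@H](CC[C@@H]3C[C@@H](O)CC(=O)O3)C12`: 40.8 nM
- compound 2 `CCC(C)(C)C(=O)O[C@H]1C[C@@H](C)[C@@H](OC(=O)NCc2ccccc2)[C@@H]2CC[C@H](C)[C@H](CC[C@@H]3C[C@@H](O)CC(=O)O3)C12`: 5 nM

Compound 2 gives the lower of the two numbers in this assay; the gap between them is an 8.2-fold lower number from compound 1 to compound 2 (0.91 log units; beyond the scatter). Compound 3 `CCC(C)(C)C(=O)O[C@H]1C[C@@H](C)[C@@H](OCCc2ccccc2)[C@@H]2CC[C@H](C)[C@H](CC[C@@H]3C[C@@H](O)CC(=O)O3)C12` differs from compound 2 in one place: phenethyl in place of benzylcarbamoyl on an oxygen on a saturated carbon. Among the compounds with values here, the only step that bears on it is an 8.2-fold lower number from compound 1 to compound 2 (0.91 log units; beyond the scatter), which came with adding benzylcarbamoyl. Compound 3 keeps the aromatic ring but not the donor or acceptor of the carbamate, so a modest rise is expected, a 2.4-fold higher number from compound 2 to compound 3 (0.38 log units; beyond the scatter). For compound 3 the estimate is 12 nM, expected to fall between 3 nM and 50 nM.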

Compound 3, half-maximal inhibitory concentration: 6 nM
For compound 3 the middle estimate is 2.0-fold (0.30 log units) above the measured one; the measured number falls inside the stated range.
By their numbers in this assay, from the lowest: compounds 2 and 3 (each within the scatter of the next); then compound 1.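

In this assay, the step, a 1.2-fold higher number from compound 2 to compound 3 (0.08 log units; within the scatter), shows that at this oxygen on a saturated carbon phenethyl matches benzylcarbamoyl, so for these compounds the hydrogen-bond donor and acceptor of benzylcarbamoyl are not required to hold the number at this level. The step from hydrogen also stands without them, at a 6.8-fold lower number from compound 1 to compound 3 (0.83 log units; beyond the scatter), which shows that the lower number does not depend on the carbamate. No evidence at hand explains this result. Left open is whether a longer chain than phenethyl, or a chain ending in an amine or a carboxylic acid, would give a similar number on this oxygen. Also open, as far as these compounds go, is whether cyclohexylethyl, which lacks the aromatic ring, would do the same.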